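The source may report more compounds than this note shows. Statements on the series, on what has been measured and on what is new or still open speak of the compounds shown alone.

Measured so far:
- compound 1, `CNC(=O)c1cc(C(=O)N[C@H]2[C@@H]3COC[C@@H]32)cc2c1O[C@H](CF)[C@H]2c1ccccc1`: 3.6 mL/min
- compound 2, `CNC(=O)c1cc(C(=O)N[C@H]2[C@@H]3COC[C@@H]32)c([C@@H](C)c2ccccc2)o1`: < 0.45 mL/min

Two compounds of the series have been run in an ADME assay on cells (Hepatocyte, Homo sapiens) for metabolic stability, read by LC-MS, with a stated time of 120 min; a lower number here means slower removal, a higher number faster removal of the compound. Compound 1, `CNC(=O)c1cc(C(=O)N[C@H]2[C@@H]3COC[C@@H]32)cc2c1O[C@H](CF)[C@H]2c1ccccc1`, gives 3.6 mL/min in this assay. Compound 2, `CNC(=O)c1cc(C(=O)N[C@H]2[C@@H]3COC[C@@H]32)c([C@@H](C)c2ccccc2)o1`, returns only < 0.45 mL/min in this assay, which is a limit of the assay and not a measured number; compound 2 therefore sits at the limit of < 0.45 mL/min in this assay, at which 1 of the 2 values shown sits, and cannot be placed more exactly than that. For the measured compounds named here, no pair of measured compounds differs in a single place, so no measured step is available, and the two values show only that compound 1 lies at a number while compound 2 lies at the limit.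

Compound 3, `CNC(=O)c1cc(C(=O)N[C@H]2CC[C@H](O)CC2)c([C@@H](C)c2ccccc2)o1`, is not yet measured. It differs from compound 2 by a group of 7 heavy atoms (6 carbon, 1 oxygen; one six-membered non-aromatic ring of carbon only) in place of a group of 6 heavy atoms (5 carbon, 1 oxygen; one three-membered non-aromatic ring of carbon only, one five-membered non-aromatic ring with 1 hetero atom), on an amide-type nitrogen. The change on the amide-type nitrogen exchanges a bicyclic ether for a 4-hydroxycyclohexyl, keeping the rest of compound 2 unchanged. Going by the values given here, with no measured step to lean on, the expectation is a step from compound 2 to compound 3 of an at least 1.3-fold higher number from compound 2 to compound 3 (0.12 log units; that floor lies within the scatter), small and within the usual scatter or slightly upward. Compound 3 is estimated at 0.6 mL/min in this assay, expected between 0.3 mL/min and 1.5 mL/min.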

Compound 3, intrinsic clearance in a liver preparation (reported as CLH), per the amount of preparation that the assay uses in the Hepatocyte assay: < 0.5 mL/min
Compound 3 was reported as a limit; the forecaster's own chance of this, stated with the estimate: 40%; middle value at least 1.2-fold (0.07 log units) from the limit.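

The step from compound 2 to compound 3 cannot be read in the Hepatocyte assay or in a physicochemical assay for solubility; a higher number here means a more soluble compound, a lower number a less soluble compound: both compounds are reported only as limits in each. In the physicochemical assay compound 2 gives >= 131 ug/mL, a limit of the assay. In the physicochemical assay compound 3 gives >= 184 ug/mL, also a limit of the assay. The compounds shown leave open how far the 4-hydroxycyclohexyl and the group it replaces on the amide-type nitrogen differ in either assay.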